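A few compounds are considered here, and "the series" means these few. Any claim that something is new, unique, unknown or untested is made for them only; others in the source may bear on it.

Working notes on the amide side chain of the shared core. In a functional assay on L6 cells (Rattus norvegicus) for inhibition, read by scintillation counting, with a stated time of 3 h (a higher number here means a weaker inhibitor, a lower number a stronger inhibitor), compound 1 (`Cc1ccc(CNC(=O)c2nc(-c3ccc(F)cc3)n(CC[C@@H](O)C[C@@H](O)CC(=O)O)c2C2CC2)cc1`) gives 178 nM, compound 2 (`O=C(O)C[C@H](O)C[C@H](O)CCn1c(-c2ccc(F)cc2)nc(C(=O)NCc2ccc(F)c(F)c2)c1C1CC1`) gives 2780 nM and compound 3 (`COc1ccc(CNC(=O)c2nc(-c3ccc(F)cc3)n(CC[C@@H](O)C[C@@H](O)CC(=O)O)c2C2CC2)cc1`) gives 6400 nM. Compound 3 therefore has the highest of the three numbers and is the weakest inhibitor of the set.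

Compound 4 (`O=C(O)C[C@H](O)C[C@H](O)CCn1c(-c2ccc(F)cc2)nc(C(=O)NCc2ccccc2)c1C1CC1`) carries hydrogen in place of methoxy on an aromatic carbon, para to a large group, so that 4-methoxybenzyl becomes benzyl: hydrogen in place of methoxy on an aromatic carbon.

Among the measured compounds shown here, three measured steps bear on this change. The closest swaps methyl for methoxy at the same place and is large: a 36-fold higher number from compound 1 to compound 3 (1.56 log units; beyond the scatter). The step between the two other ring patterns is modest: a 2.3-fold higher number from compound 2 to compound 3 (0.36 log units; beyond the scatter). The remaining step is large and shows how far ring substitution alone can move the number: a 16-fold higher number from compound 1 to compound 2 (1.19 log units; beyond the scatter). For the measured compounds named here, no measured compound has an unsubstituted ring, so the data do not fix where hydrogen falls within this span.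

A moderate move toward stronger inhibition in this assay seems most likely, smaller than the step seen with methyl. The expected change is a 4.3-fold lower number from compound 3 to compound 4 (0.63 log units; beyond the scatter). For compound 4 the estimated value is 1500 nM, with an expected range from 300 nM to 6000 nM.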

Compound 4, half-maximal inhibitory concentration: 632 nM
Compound 4: middle estimate off by 2.4-fold (0.38 log units), on the high side; the measured number falls inside the stated range.
By their numbers in this assay, from the lowest: compound 1; then compound 4; then compound 2; then compound 3.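

Benzyl supplies the unsubstituted reference that was missing: in this assay, removing methoxy gives (a 10-fold lower number from compound 3 to compound 4 (1.01 log units; beyond the scatter)) while removing methyl from the same aromatic carbon moves the number the other way (a 3.6-fold higher number from compound 1 to compound 4 (0.55 log units; beyond the scatter)), so hydrogen lies between these two groups and the two substituents act in opposite directions relative to it. The step to benzyl from the other substituted ring (a 4.4-fold lower number from compound 2 to compound 4 (0.64 log units; beyond the scatter)) shows that 3,4-difluorophenyl also gives a higher number than phenyl, so among the three substituted rings only the 4-methylphenyl of compound 1 improves on phenyl, while compound 2 and compound 3 go against any general gain from ring substitution. Nothing available explains this order or the separate contributions of these groups.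

The compounds shown leave open whether the gain with methyl extends to a longer chain such as ethyl, and where a chlorine, a hydroxyl or an amine on the same aromatic carbon would fall relative to hydrogen. They also leave open how a single fluorine would compare with phenyl, since the only fluorinated benzyl here carries two fluorines.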